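Trading a Carboxy End for a Hydroxyethyl End

The source may report more compounds than this note shows. Statements on the series, on what has been measured and on what is new or still open speak of the compounds shown alone.

Compound 1 `CC(C)(C)c1ccc(C(=O)N2CCC3(CC2)C(=O)N(CC(=O)NCCC(=O)O)CN3c2ccccc2)cc1` closes its side chain with a carboxy group. In an assay on HEK293 cells for displacement of a labelled ligand from NPC1-like intracellular cholesterol transporter 1 (Homo sapiens) (on this read-out higher numbers stand for weaker inhibition and lower numbers for stronger inhibition), compound 1 gives 11400 nM, the highest of the three numbers measured, which on this read-out means the weakest binding. Compound 2 `O=C(CN1CN(c2ccccc2)C2(CCN(C(=O)c3ccc(C4CCCCC4)cc3)CC2)C1=O)N1CCCCC1` differs from compound 1 at more than one place; in this assay compound 2 gives 1100 nM. Compound 3 `CC(C)(C)OC(=O)NCNC(=O)CN1CN(c2ccccc2)C2(CCN(C(=O)c3ccc(C4CCCCC4)cc3)CC2)C1=O` gives 1700 nM. Among the measured compounds shown here, the only step between two compounds that differ in a single place is a 1.5-fold higher number from compound 2 to compound 3 (0.19 log units; within the scatter), showing that exchanging the group on that amide carbonyl leaves the binding essentially unchanged.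

Compound 4 `CC(C)(C)c1ccc(C(=O)N2CCC3(CC2)C(=O)N(CC(=O)NCCCCO)CN3c2ccccc2)cc1` is compound 1 with one change: 2-hydroxyethyl in place of carboxy on a saturated chain carbon, two bonds along the chain from an amide-type nitrogen. For the measured compounds named here, no measured pair isolates this exchange. The step from compound 2 to compound 3 concerns a different part of the chain and lay within the scatter, so it offers no direct guide. Compound 1 is the only acid in the set and also the weakest binder, but it differs from compounds 2 and 3 elsewhere too, so these numbers alone cannot pin the weakness on the carboxy group. A cautious expectation is a modest improvement: compound 4 is estimated at 6000 nM, with a likely range from 2000 nM to 18000 nM, which corresponds to an expected step of a 1.9-fold lower number from compound 1 to compound 4 (0.28 log units; within the scatter).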

Compound 4, half-maximal inhibitory concentration: 19200 nM
Beside the measured number, compound 4's estimate is 3.2-fold (0.51 log units) below it; the whole stated range lies below it.
By their numbers in this assay, from the lowest: compounds 2 and 3 (each within the scatter of the next); then compounds 1 and 4 (each within the scatter of the next).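

In this assay, replacing the carboxy end with 2-hydroxyethyl gives a 1.7-fold higher number from compound 1 to compound 4 (0.23 log units; within the scatter), so this exchange at this position cannot be told apart from repeated measurement of a single compound. The earlier compounds shown here left open whether the carboxy group accounted for the high number of compound 1, and this pair now shows that removing it, with a group of the same heavy-atom count and the same counts of hydrogen-bond donors and acceptors put in its place, brings no measurable gain in binding. No measurement is available that explains why the two ends read alike.

On these data alone, whether any other end on this chain can move the number is still open, for example an amine or a methyl ester in place of the hydroxy or carboxy group. Also unresolved is how much of the gap between compounds 1 and 4 on one side and compounds 2 and 3 on the other belongs to the tert-butyl group as against the cyclohexyl group, since those compounds differ in more than one place.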